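Compound 3 and the Limit Reached by Compound 2

A few compounds are considered here, and "the series" means these few. Any claim that something is new, unique, unknown or untested is made for them only; others in the source may bear on it.

Values in a functional assay on aorta (Rattus norvegicus, strain Sprague-Dawley) for inhibition; on this read-out higher numbers stand for an effect only at larger amounts of compound and lower numbers for an effect already at smaller amounts:
Compound 1 `Cc1cc2c(c3c1C[C@@H]1[C@@H](C)CO[C@]1(C)O3)C[C@@H]1[C@@H](C)CO[C@]1(C)O2`: 52000 nM
Compound 2 `C[C@H]1CO[C@]2(C)Oc3cc(OC/C=C/c4ccccc4)c4c(c3C[C@H]12)O[C@@]1(C)OC[C@H](C)[C@H]1C4`: > 200000 nM (a limit)

In this assay compound 2 stands at > 200000 nM, which is a limit of the assay and not a number. Compound 3 `CCCCOc1cc2c(c3c1C[C@@H]1[C@@H](C)CO[C@]1(C)O3)C[C@@H]1[C@@H](C)CO[C@]1(C)O2` differs from compound 2 by propyl in place of 2-phenylethenyl on a saturated chain carbon bound to an oxygen on an aromatic ring. Read one bond further out, butoxy replaces (3-phenylprop-2-en-1-yl)oxy. Among the measured compounds shown here, one measured step bears on this change: an at least 3.8-fold higher number from compound 1 to compound 2 (0.58 log units; beyond the scatter). That step put (3-phenylprop-2-en-1-yl)oxy in place of methyl on an aromatic carbon. As far as these compounds go, for compound 2 the full size of that step stays open because of the limit of > 200000 nM in this assay, at which 1 of the 2 values shown sits. Compound 3 keeps an oxygen-linked chain but loses the 2-phenylethenyl part, so it is expected to fall only part of the way back towards compound 1 at 52000 nM. A modest move to a lower number is expected in this assay, an estimated at least 1.8-fold lower number from compound 2 to compound 3 (0.25 log units; that floor lies within the scatter). With a single step behind it, this expectation is loose, and compound 3 may also reach the limit. For compound 3 the estimated value is 110000 nM, with an expected range of 40000 nM to 300000 nM.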

Compound 3, half-maximal effective concentration: > 200000 nM
Compound 3: no number, only a limit (the forecaster's own chance of this, stated with the estimate: 35%); middle value at least 1.8-fold (0.25 log units) away from the limit.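

In this assay compound 3 gives > 200000 nM, which is a limit of the assay and not a number. Butoxy in place of methyl on an aromatic carbon gives an at least 3.8-fold higher number from compound 1 to compound 3 (0.58 log units; beyond the scatter), the same reading as an at least 3.8-fold higher number from compound 1 to compound 2 (0.58 log units; beyond the scatter), so the 2-phenylethenyl part is not needed for an oxygen-linked chain on this carbon to move the value beyond the scatter; no compound shown goes against this. The step between compound 2 and compound 3, propyl in place of 2-phenylethenyl on a saturated chain carbon bound to an oxygen on an aromatic ring, cannot be read, because both compounds stand at the limit: the limit of > 200000 nM in this assay, at which 2 of the 3 values shown sit.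

As far as these compounds go, the true size of both steps from compound 1 stays open, as does any ranking of butoxy against (3-phenylprop-2-en-1-yl)oxy. From the compounds shown here alone, it also remains open whether the oxygen link or the chain beyond it goes with the change, which a methoxy or hydroxy group on the same aromatic carbon, or an amine at the end of the butoxy chain, could begin to separate.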